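A few compounds are considered here, and "the series" means these few. Any claim that something is new, unique, unknown or untested is made for them only; others in the source may bear on it.

In a functional assay on CEM-SS cells (Homo sapiens) for cytotoxicity (on this read-out lower numbers stand for stronger inhibition and higher numbers for weaker inhibition), compound 1 `CC(C)(C)c1ccc(Cn2c(N)nc3cc(Cl)c(Cl)cc32)cc1` gives 27000 nM as its measured value.

Compound 2 `Cc1ccc(Cn2c(Br)nc3cc(Cl)c(Cl)cc32)cc1` stands only at a limit of the assay, > 100000 nM and not a number.

Compound 3 `CC(C)(C)c1ccc(Cn2c(Br)nc3cc(Cl)c(Cl)cc32)cc1` differs from compound 2 by tert-butyl in place of methyl on an aromatic carbon, para to a large group tert-butyl in place of methyl on an aromatic carbon in the counted change.

For the measured compounds named here, no measured pair isolates this change. A step toward stronger inhibition is expected in this assay because compound 1 with its tert-butyl gives 27000 nM there.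

The estimate implies an at least 2.5-fold lower number from compound 2 to compound 3 (0.39 log units; beyond the scatter) as the expected step.

For compound 3 the expected value is 40000 nM within an estimated range from 15000 nM to 100000 nM in this read-out.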

Compound 3, half-maximal inhibitory concentration: > 100000 nM
Compound 3 gave a limit, no number; the forecaster's own chance of this, stated with the estimate: 30%; middle value at least 2.5-fold (0.39 log units) away from the limit.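

In this assay, the step for tert-butyl in place of methyl on an aromatic carbon cannot be read, because compound 2 and compound 3 both stand at a limit and not at a number: the limit of > 100000 nM in this assay, at which 2 of the 3 values shown sit. With tert-butyl held constant, bromo in place of amino gives an at least 3.7-fold higher number from compound 1 to compound 3 (0.56 log units; beyond the scatter). Tert-butyl with bromo thus stays without a readable value, and in this pair the exchange of amino for bromo is what separates the readable value from the limit.

From the compounds shown here alone, whether a methylamino group or a hydroxyl in that place would give a readable value remains open. So does whether methyl with amino would read like tert-butyl with amino.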